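The source may report more compounds than this note shows. Statements on the series, on what has been measured and on what is new or still open speak of the compounds shown alone.

In an assay on CHO cells for displacement of a labelled ligand from adenosine receptor A1 (Homo sapiens), read by scintillation counting, with a stated time of 3 h (on this read-out higher numbers stand for weaker inhibition and lower numbers for stronger inhibition), compound 2, with the structure `Nc1nc(-c2ccc(CO)cc2)nc2sc(-c3ccco3)nc12`, gives 77.7 nM. Of the two compounds with numbers in this assay, compound 2 stands lowest, and its nearest neighbour is compound 1, structure `COc1ccc(-c2nc(N)c3nc(-c4ccccc4)sc3n2)cc1`, whose value of 225 nM lies beyond the usual scatter of the measurement. Going by the values given here, compound 1 and compound 2 differ at two positions at once, so their two values show only that the pair taken together spans a moderate gap, not which change carries it.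

Compound 3, structure `COc1ccc(-c2nc(N)c3nc(-c4ccco4)sc3n2)cc1`, is built from compound 2 by a single exchange: methoxy in place of hydroxymethyl on an aromatic carbon. The two molecules hold the same atoms joined differently. Among the compounds with values here, no pair of measured compounds separates this exchange on its own, so no measured step can be quoted for it. The expectation for this step is a small one, in the direction of a somewhat higher number or none beyond the scatter, since the group that enters keeps the acceptor but loses the donor. Compound 3 is therefore expected to give about 110 nM in this assay, within a range from 40 nM to 320 nM, an estimated step of a 1.4-fold higher number from compound 2 to compound 3 (0.15 log units; within the scatter).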

Compound 3, inhibition constant: 47.7 nM
Compound 3: the middle estimate sits 2.3-fold (0.36 log units) above what was measured; measured number inside the range.
By their numbers in this assay, from the lowest: compounds 3 and 2 (each within the scatter of the next); then compound 1.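

In this assay the exchange of hydroxymethyl for methoxy on the aromatic carbon para to a large group gives a 1.6-fold lower number from compound 2 to compound 3 (0.21 log units; within the scatter), so at this position the hydrogen-bond donor of hydroxymethyl can go without the number moving beyond the scatter. The gap between compound 1 and compound 2, which spanned two changes at once, can now be read in single steps: furan-2-yl in place of phenyl on an aromatic carbon gives a 4.7-fold lower number from compound 1 to compound 3 (0.67 log units; beyond the scatter), a modest step, and it is the only one of the two single exchanges that lies beyond the scatter. Nothing among the data shown gives a reason for either step.

The compounds shown leave open whether an amine, a carboxylic acid or a longer chain such as ethoxy at this same position would also stay within the scatter of methoxy and hydroxymethyl. From the compounds shown here alone, each exchange also rests on a single pair, so it remains open whether the methoxy and hydroxymethyl exchange reads the same with phenyl in place of furan-2-yl.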